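The compounds below may be only part of what the source reports. "The series", "measured", "known", "first", "only" and "open" are said of these compounds alone.

Compound 1 `COc1cc(-c2cc(/C=C/C(=O)c3ccc(N)cc3)[nH]n2)cc(OC)c1OC` gives 94% in a functional assay on PC-3 cells (Homo sapiens) for cytotoxicity, read by sulforhodamine B assay, with a stated time of 48 h, tested at 0.1 uM (on this read-out lower numbers stand for a stronger effect and higher numbers for a weaker effect at the one concentration tested), and stands lowest of the two numbers measured, its nearest neighbour being compound 2 `COc1cc(-c2cc(/C=C/C(=O)c3ccc(Cl)c(Cl)c3)[nH]n2)cc(OC)c1OC`, which gives 100%. Going by the values given here, the single measured step, a number 6 percentage points higher from compound 1 to compound 2 (within the scatter), lies within the scatter. Compound 3 `COc1ccc(-c2cc(/C=C/C(=O)c3ccc(N)cc3)[nH]n2)cc1OC` differs from compound 1 in one place: hydrogen in place of methoxy on an aromatic carbon. Among the compounds with values here, no measured step touches a methoxy group, and both measured numbers already sit near the weak end of the scale. Compound 3 is therefore expected to give about 96%, estimated between 84% and 102%. The expected step, a number 2 percentage points higher from compound 1 to compound 3 (within the scatter), is not anticipated to exceed the scatter.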

Compound 3, a percentage reported as activity, at one concentration (the size of the read-out at that concentration, not a potency): 95%
For compound 3 the middle estimate is 1 percentage points above the measured one; the measured number falls inside the stated range.
By their numbers in this assay, from the lowest: compounds 1, 3 and 2 (each within the scatter of the next).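

Hydrogen in place of methoxy on an aromatic carbon gives a number 1 percentage points higher from compound 1 to compound 3 (within the scatter) in this assay and so, unlike the earlier step, tests this position on the methoxy-bearing ring. At the one concentration tested, this methoxy group makes no difference that stands out from the scatter, although compound 1 already reads near the weak end of the scale. Nothing available accounts for this result.

Going by these compounds, whether a hydroxyl group, an amine or a longer alkoxy chain at this place would move the number remains open. So does whether the methoxy group matters at other concentrations.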